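This account rests on a few compounds, and the source may have more. Where it says the series, first, only, none or still open, it means among the compounds named here.

Four compounds share one core, and their values in a functional assay on U-87MG ATCC cells (Homo sapiens) for antiproliferative activity, read by MTT assay, with a stated time of 48 h (a lower number here means a stronger inhibitor, a higher number a weaker inhibitor), set the scene. Compound 1 `COc1cc(N/C=C\C(=O)c2cn(-c3ccccc3)nc2-c2ccc(F)cc2)cc(OC)c1OC` gives 12600 nM in this assay. Compound 2 `COc1ccc(-c2nn(-c3ccccc3)cc2C(=O)/C=C\Nc2ccc(Cl)cc2)cc1` gives 8860 nM in this assay. Compound 3 `COc1ccc(N/C=C\C(=O)c2cn(-c3ccccc3)nc2-c2ccc(OC)cc2)cc1` reaches only the limit of this assay, > 50000 nM, so for compound 3 a limit and not a number is known; this is the limit of > 50000 nM in this assay, at which 1 of the 3 values shown sits. Among the measured compounds shown here, the one measured single change, an at least 5.6-fold higher number from compound 2 to compound 3 (0.75 log units; beyond the scatter), moves the number in the weakening direction, and it concerns a different place than the change now at hand. Compound 4 `COc1ccc(-c2nn(-c3ccccc3)cc2C(=O)/C=C\Nc2cc(OC)c(OC)c(OC)c2)cc1` differs from compound 3 in that (3,4,5-trimethoxyphenyl in place of 4-methoxyphenyl on an amine nitrogen). Compound 1 also carries the 3,4,5-trimethoxyphenyl group on its amine nitrogen and gives a number within the measured range of this assay. For the measured compounds named here, no measured step covers the change from compound 3 to compound 4, so the expectation leans on the numbers of compound 1 and compound 2 and rests on little. Compound 4 is therefore expected to give about 20000 nM in this assay, between 6000 nM and 60000 nM, a step of an at least 2.5-fold lower number from compound 3 to compound 4 (0.39 log units; beyond the scatter) estimated in the strengthening direction.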

Compound 4, half-maximal inhibitory concentration: > 50000 nM
Compound 4: only a limit was reported; the forecaster's own chance of this, stated with the estimate: 30%; middle value at least 2.5-fold (0.39 log units) from the limit.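

In this assay, the 3,4,5-trimethoxyphenyl group on the amine nitrogen does not by itself keep a compound within the measured range: swapping the fluoro group for a methoxy group gives an at least 3.9-fold higher number from compound 1 to compound 4 (0.59 log units; beyond the scatter). Putting 3,4,5-trimethoxyphenyl in place of 4-chlorophenyl on the amine nitrogen gives an at least 5.6-fold higher number from compound 2 to compound 4 (0.75 log units; beyond the scatter), the same direction as the earlier change to 4-methoxyphenyl. The change from compound 3 to compound 4 cannot be read, because both compounds stop at a limit and not at a number: the limit of > 50000 nM in this assay, at which 2 of the 4 values shown sit.

From the compounds shown here alone, whether 3,4,5-trimethoxyphenyl and 4-methoxyphenyl differ at all on this nitrogen therefore stays open. Also open, going by these compounds, is whether an amine or a carboxylic acid on the phenyl ring at this nitrogen would bring the number back into the measured range.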